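From an Ethoxycarbonyl to a Carbamoyl Group

A few compounds are considered here, and "the series" means these few. Any claim that something is new, unique, unknown or untested is made for them only; others in the source may bear on it.

Compound 3 `CCOC(=O)c1sc(-c2cccc(NC(=O)c3ccc(F)c(Cl)c3)c2)nc1Nc1ccc(N2CCN(C)CC2)cc1` gives "not determined" (no result reported) in a functional assay on Raji cells (Homo sapiens) for antiproliferative activity, read by CCK-8 assay, with a stated time of 72 h; a lower number here means a stronger inhibitor, a higher number a weaker inhibitor. Its close relatives give little more: compound 1 `CCOC(=O)c1sc(-c2cccc(NC(=O)c3ccccc3)c2)nc1Nc1ccc(N2CCN(C)CC2)cc1` gives "not determined" (no result reported) there, while compound 2 `CCOC(=O)c1sc(-c2cccc(NC(=O)c3ccc(C#N)cc3)c2)nc1Nc1ccc(N2CCN(C)CC2)cc1` gives 14000 nM in this assay. So compound 3 stands without a number of its own, and only compound 2 offers a measured point in this set.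

Compound 4 `CN1CCN(c2ccc(Nc3nc(-c4cccc(NC(=O)c5ccc(F)c(Cl)c5)c4)sc3C(N)=O)cc2)CC1` differs from compound 3 in one place: amino in place of ethoxy on a carbonyl carbon. For the measured compounds named here, no step between two measured compounds is available to size this change, so any expectation is loosely held. The author expects a shift toward a stronger inhibitor in this assay, of modest size rather than beyond doubt, since the change replaces ethoxy with amino and nothing measured here contradicts it. Because compound 2 gives 14000 nM, that single value anchors the guess. Compound 4 is estimated at 3000 nM, within a range from 500 nM to 20000 nM.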

Compound 4, half-maximal inhibitory concentration: 6230 nM
Compound 4: the middle estimate sits 2.1-fold (0.32 log units) below what was measured, and the stated range covers the measured number.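

In this assay, for the compounds shown here, compound 3 has no single number, and no step from it to compound 4 can be read. From the compounds shown here alone, what the change from ethoxycarbonyl to carbamoyl does in this assay stays open, and no further data bear on this result.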